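The source may report more compounds than this note shows. Statements on the series, on what has been measured and on what is new or still open speak of the compounds shown alone.

Measured compounds:
compound 1 `CC(C)Cc1ccc(C(=O)/C=C/c2ccc(C(=O)O)cc2)cc1` — < 10 ug/mL in an ADME assay on Vero cells (Chlorocebus sabaeus) for cytotoxicity, read by MTT assay, with a stated time of 72 h; a higher number here means that more compound is tolerated, a lower number that less compound is tolerated
compound 2 `CCCOc1ccc(C(=O)/C=C/c2ccc(C(=O)Nc3cccc(-c4cc(C(=O)OC)no4)c3)cc2)cc1` — > 40 ug/mL
compound 3 `CCOC(=O)c1nnn(-c2cccc(NC(=O)c3ccc(/C=C/C(=O)c4ccc(Cl)cc4)cc3)c2)c1C` — "not determined" (no result reported)

Three compounds share the chalcone-type core of compound 1. For compound 1 the result is only a limit, < 10 ug/mL, at the lower edge of the assay (the limit of < 10 ug/mL in this assay, at which 1 of the 3 values shown sits). For compound 2 the result is likewise a limit, > 40 ug/mL, at the upper edge (the limit of > 40 ug/mL in this assay, at which 1 of the 3 values shown sits). For compound 3 no result was reported. Compound 2 therefore stands at the tolerated end of what this set shows, but with a limit rather than a number, so its true position is open. Going by the values given here, no two measured compounds differ in a single place, so no measured step is available to calibrate the change that follows.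

Compound 4 `COC(=O)c1cc(-c2cccc(NC(=O)c3ccc(/C=C/C(=O)c4cccc(Br)c4)cc3)c2)on1` is not yet measured. It differs from compound 2 as follows: 3-bromophenyl in place of 4-propoxyphenyl on a carbonyl carbon. Without any measured step to lean on, the expectation is a step from compound 2 to compound 4 of a number no higher from compound 2 to compound 4 (the limit leaves the size open), that is, no change beyond the scatter, since compound 2 sits at a limit and the amide-linked portion is kept. Compound 4 is estimated at 40 ug/mL, within 20 ug/mL to 80 ug/mL.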

Compound 4, half-maximal cytotoxic concentration: > 100 ug/mL
Compound 4 ended at the assay's limit; the forecaster's own chance of this, stated with the estimate: 55%; at least 2.5-fold (0.39 log units) between middle value and limit.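

Going by these compounds alone, the results for compound 2 and compound 4 are both limits, so no step between the two can be read in this assay. The compounds shown leave open how much of either compound is actually tolerated, and whether 3-bromophenyl in place of 4-propoxyphenyl on a carbonyl carbon changes that tolerance at all.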